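Swapping propyl for trifluoromethyl on a fused core

A few compounds are considered here, and "the series" means these few. Any claim that something is new, unique, unknown or untested is made for them only; others in the source may bear on it.

Two compounds have been measured in a functional assay on the whole organism (artery) with Rattus norvegicus as the target, with a stated time of 60 min, at a dose of 3 mg/kg by the intraduodenal route; a higher number here means more inhibition at the dose given (going by the name of the read-out), a lower number less inhibition:

compound 1, `CCCc1nc(C)nc2c1CCC(=O)N2Cc1ccc(-c2ccccc2-c2nn[nH]n2)cc1`, giving -86%
compound 2, `Cc1nc(C)c2c(n1)N(Cc1ccc(-c3ccccc3-c3nn[nH]n3)cc1)CCC2`, giving -20%

In this assay compound 1 stands lowest of the two numbers; its nearest neighbour, compound 2, lies higher, a gap beyond the scatter. Within the data shown here, both compounds carry the same biphenyl-tetrazole arm on a nitrogen of the shared core and differ in the core itself, so no single-point step between them can be drawn and their two values can only be set side by side.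

Compound 3, `Cc1nc2c(c(C(F)(F)F)n1)CCC(=O)N2Cc1ccc(-c2ccccc2-c2nn[nH]n2)cc1`, has not yet been measured. It differs from compound 1 in one place: trifluoromethyl in place of propyl on an aromatic carbon. The carbonyl of compound 1 is kept.

Among the measured compounds shown here, no measured pair shows what this swap does, so the step of a number 36 percentage points higher from compound 1 to compound 3 (beyond the scatter) is an estimate only; a moderate shift toward less negative numbers is expected, since the value of compound 1 at -86% leaves more room upward than downward. For compound 3 a value of about -50% is expected, within a range from -95% to 0%.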

Compound 3, a percentage reported as inhibition, in the whole organism at one dose (the size of the read-out at that dose, not a potency): -68%
Beside the measured number, compound 3's estimate is 18 percentage points above it, within the range that was stated.
By their numbers in this assay, from the lowest: compound 1; then compound 3; then compound 2.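

Among these compounds, this is the first change at a single place that can be read in this assay: with the carbonyl, the methyl group and the biphenyl-tetrazole arm all kept, trifluoromethyl in place of propyl on the aromatic carbon next to the ring nitrogen gives a number 18 percentage points higher from compound 1 to compound 3 (beyond the scatter). The step is modest but beyond the scatter, so the number in this assay does depend on which group sits at this position, something the earlier pair, whose cores differ, could not show. Neither group carries a hydrogen-bond donor or acceptor, so the step comes without any change in those counts, and nothing available here tells why the number moves.

From the compounds shown here alone, one step between two groups gives no trend for this position, so it remains open how a longer chain such as butyl, a small ring such as cyclopropyl, an amine or a carboxylic acid would read here. Going by these compounds, it is also open whether the same swap would move the number in the same direction on the core of compound 2, which has no carbonyl.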